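Compounds 1 and 2 and the next sulfur-linked group

The source may report more compounds than this note shows. Statements on the series, on what has been measured and on what is new or still open speak of the compounds shown alone.

Measured in a functional assay on NCI-H1975 cells (Homo sapiens) for inhibition, read by MTT assay, with a stated time of 72 h; a higher number here means a weaker inhibitor, a lower number a stronger inhibitor
compound 1 (`FC(F)(F)c1ccc(CSc2nc(N3CCN(c4ccccn4)CC3)cc(C(F)(F)F)n2)cc1`) gives 17400 nM
compound 2 (`FC(F)(F)c1ccc(CSc2nc(Sc3nnnn3-c3ccccc3)cc(C(F)(F)F)n2)cc1`) gives 24300 nM

In this assay compound 2 stands level with compound 1, since the two values lie within the scatter of each other and neither ranks ahead. Compound 3 (`FC(F)(F)c1ccc(CSc2nc(Sc3ncc(-c4ccncc4)s3)cc(C(F)(F)F)n2)cc1`) has 5-(pyridin-4-yl)-1,3-thiazol-2-yl in place of 1-phenyl-1H-tetrazol-5-yl on a sulfur. Among the measured compounds shown here, no measured single-place step is available to size this change, so the expectation rests on the two values alone. Both sit in one narrow band, and no step beyond the scatter is expected in this assay. The expected change is small, at a 1.4-fold lower number from compound 2 to compound 3 (0.16 log units; within the scatter) (an estimate that stays within the scatter). For compound 3 the estimated value is 17000 nM (expected range 6500 nM to 40000 nM).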

Compound 3, half-maximal inhibitory concentration: 16700 nM
For compound 3 the middle estimate is 1.0-fold (0.01 log units) above the measured one; measured number inside the range.
By their numbers in this assay, from the lowest: compounds 3, 1 and 2 (each within the scatter of the next).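

Among the compounds shown here, on the sulfur whose other neighbour is an aromatic carbon, 5-(pyridin-4-yl)-1,3-thiazol-2-yl in place of 1-phenyl-1H-tetrazol-5-yl gives a 1.5-fold lower number from compound 2 to compound 3 (0.16 log units; within the scatter) in this assay as the only single-place step in this set. It shows that, at this position, exchanging one two-ring aromatic group for another with the same heavy-atom count, but with different ring hetero atoms and one hydrogen-bond acceptor fewer, gives no difference beyond the scatter. No measurement shown here explains why the two groups read alike.

Still open, as far as these compounds go, is whether any group on this sulfur separates from this narrow band in this assay at all. A small group such as a short alkyl chain ending in a carboxylic acid or a primary amine would test that, as neither appears among the compounds shown.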